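The source may report more compounds than this note shows. Statements on the series, on what has been measured and on what is new or still open speak of the compounds shown alone.

Measured compounds:
- compound 1, `CCCc1nc(-c2ccccc2)c(CNCCN2CCN(c3cccc(C(F)(F)F)c3)CC2)o1`, in an assay on HEK293 cells for inhibition of Voltage-dependent T-type calcium channel subunit alpha-1G (Homo sapiens), read by fluorescence, tested at 10 uM (on this read-out higher numbers stand for more inhibition at the one concentration tested (going by the name of the read-out) and lower numbers for less inhibition), gives 56.3%
- compound 2, `CCCc1nc(-c2ccccc2)c(CNCCN2CCN(c3cccc(OC)c3)CC2)o1`, in this assay gives 40.2%
- compound 3, `Cc1nc(-c2ccccc2)c(CNCCN2CCN(C(c3ccccc3)c3ccccc3)CC2)o1`, in this assay gives 57.3%

Among these three numbers compound 2 stands lowest, with compound 1 higher by a step beyond the scatter and compound 3 further away still. Among the measured compounds shown here, the only one-place step measured here is a number 16.1 percentage points lower from compound 1 to compound 2 (beyond the scatter), which shows that swapping the group on the aromatic carbon of the shared core moves the read-out by a modest but real amount. Compound 4, `CCCc1nc(-c2ccccc2)c(CNCCN2CCN(c3cccc(C)c3)CC2)o1`, carries a methyl at that same position: methyl in place of methoxy on an aromatic carbon. For the measured compounds named here, no measured pair shows a methyl against a methoxy, so the direction of this step cannot be read off directly; the one step available only shows that this position matters. Because the drop seen in a number 16.1 percentage points lower from compound 1 to compound 2 (beyond the scatter) was modest, compound 4 is expected to land close to compound 2, with a slight upward lean that may well stay within the scatter, as a number 6.8 percentage points higher from compound 2 to compound 4 (within the scatter). Compound 4 is therefore estimated at 47%, in a range from 32% to 62%.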

Compound 4, a percentage reported as inhibition, at one concentration (the size of the read-out at that concentration, not a potency): 43.1%
Estimate against measurement, compound 4: 3.9 percentage points above, within the range that was stated.
By their numbers in this assay, from the lowest: compounds 2 and 4 (each within the scatter of the next); then compounds 1 and 3 (each within the scatter of the next).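

In this assay, the change from 3-methoxyphenyl to 3-methylphenyl gives a number 2.9 percentage points higher from compound 2 to compound 4 (within the scatter), so this read-out does not separate the two groups, even though methyl has one heavy atom fewer and no hydrogen-bond acceptor. Replacing trifluoromethyl with methyl gives a number 13.2 percentage points lower from compound 1 to compound 4 (beyond the scatter), so methyl and methoxy each stand apart from trifluoromethyl at this position, and the earlier drop is not specific to methoxy. Nothing available explains why trifluoromethyl stands apart from the other two groups.

As far as these compounds go, it remains open whether chlorine, a nitrile or an amine on this aromatic carbon would group with trifluoromethyl or with methyl and methoxy. From the compounds shown here alone, it is also open whether trifluoromethyl would keep its higher number on a different carbon of this ring.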